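This account rests on a few compounds, and the source may have more. Where it says the series, first, only, none or still open, it means among the compounds named here.

Measured so far:
compound 1 `CN1CCN(CC(=O)NC2(c3ccc(Cl)cc3)C(=O)Nc3cc(Cl)c(Cl)cc32)CC1` — > 10000 nM
compound 2 `CN1CCCN(CC(=O)NC2(c3ccc(Cl)c(Cl)c3)C(=O)Nc3cc(Cl)cc(Cl)c32)CC1` — 64 nM

In an in vitro functional assay on CHO-CREluc cells for antagonist activity at growth hormone secretagogue receptor type 1 (Homo sapiens), read by a luciferase reporter, with a stated time of 4 h (on this read-out lower numbers stand for stronger inhibition and higher numbers for weaker inhibition), compound 1 gives only a limit, > 10000 nM. Among the compounds with values here, compound 2 is the sole compound with a number in this assay and so stands alone; no step between measured compounds can be read. Compound 3 `CCN1CCC(CC(=O)NC2(c3ccc(Cl)c(Cl)c3)C(=O)Nc3cc(Cl)cc(Cl)c32)CC1` is not yet measured. It differs from compound 2 by 1-ethylpiperidin-4-yl in place of 4-methyl-1,4-diazepan-1-yl on a saturated chain carbon bound to a carbonyl carbon; both groups carry a basic amine, so no large shift is expected, and the step from compound 2 to compound 3 is estimated as a 1.9-fold higher number from compound 2 to compound 3 (0.27 log units; within the scatter), close to the scatter. Compound 3 is expected at 120 nM, between 30 nM and 600 nM.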

Compound 3, half-maximal inhibitory concentration: 1 nM
The estimate for compound 3 lay 120-fold (2.08 log units) above the measured number, outside the stated range (below it).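

In this assay, the group on a saturated chain carbon bound to a carbonyl carbon proves to be a highly sensitive point in the series: 1-ethylpiperidin-4-yl in place of 4-methyl-1,4-diazepan-1-yl gives a 64-fold lower number from compound 2 to compound 3 (1.81 log units; beyond the scatter). The two groups have the same heavy-atom count, so that count alone does not account for the step. Nothing in the data at hand explains the gain.

The change alters ring size, ring nitrogen count and the substituent on nitrogen together, and these contributions cannot be separated here. Going by these compounds, it remains open whether 1-methylpiperidin-4-yl or 4-ethylpiperazin-1-yl would retain the value of compound 3.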